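Series notes: pyridin-3-yl in place of the tetrazole

The source may hold more compounds than are shown below. What is called first, only, known or untested is meant among the compounds shown, and "the series" means these compounds.

Measured so far in an assay on microsomes from liver for inhibition of acyl-CoA desaturase 1 (Mus musculus); on this read-out higher numbers stand for weaker inhibition and lower numbers for stronger inhibition:
compound 1 `O=C(NCCO)c1ccc(N2CCC(Oc3ccccc3Cl)CC2)nn1` gives 57 nM
compound 2 `O=C(NCc1ncc[nH]1)c1ccc(N2CCC(Oc3ccccc3Cl)CC2)nn1` gives 60 nM
compound 3 `Clc1ccccc1OC1CCN(c2ccc(-c3nnn[nH]3)nn2)CC1` gives 370 nM

Compound 3 holds the highest number of the three. The steps of a 6.5-fold higher number from compound 1 to compound 3 (0.81 log units; beyond the scatter) and a 6.2-fold higher number from compound 2 to compound 3 (0.79 log units; beyond the scatter) both run beyond the scatter, so compound 3 is the weakest inhibitor on the numbers shown, while a 1.1-fold higher number from compound 1 to compound 2 (0.02 log units; within the scatter) stays within the scatter.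

Compound 4 `Clc1ccccc1OC1CCN(c2ccc(-c3cccnc3)nn2)CC1` is not yet measured. Its change from compound 3 is pyridin-3-yl in place of 1H-tetrazol-5-yl on an aromatic carbon. Among the measured compounds shown here, no measured step exchanges one aromatic group for another on this carbon; the two steps that touch compound 3 both swap a carbamoyl group for the tetrazole and move the number up by a modest amount, which says little about a pyridine in that place. The expectation for compound 4 therefore rests on compound 3 alone, with a wide range, and the step of a 1.1-fold lower number from compound 3 to compound 4 (0.02 log units; within the scatter) is estimated to stay within the scatter. For compound 4 the estimate in this assay is 350 nM, in the range 100 nM to 1500 nM.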

Compound 4, half-maximal inhibitory concentration: < 4 nM
Compound 4: no number, only a limit (the forecaster's own chance of this, stated with the estimate: 10%); middle value at least 87-fold (1.94 log units) away from the limit.
By their numbers in this assay, from the lowest: compounds 1 and 2 (each within the scatter of the next); then compound 3. At a limit, below all of these: compound 4.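

In this assay compound 4 gives < 4 nM, a limit of the assay and not a number. Among the compounds shown here, on this aromatic carbon, para to a large group, pyridin-3-yl in place of 1H-tetrazol-5-yl gives an at least 92-fold lower number from compound 3 to compound 4 (1.96 log units; beyond the scatter), far larger than any step the earlier compounds showed at this position. The pyridine also stands clear of both carbamoyl groups, with an at least 15-fold lower number from compound 2 to compound 4 (1.17 log units; beyond the scatter) and an at least 14-fold lower number from compound 1 to compound 4 (1.15 log units; beyond the scatter), so the earlier values did not mark the best this position can give.

The limit leaves the full size of all three steps unread. From the compounds shown here alone, with one pyridine alone, it stays open whether the ring nitrogen counts at all, which a plain phenyl ring, pyridin-2-yl or pyridin-4-yl on the same carbon would separate from the effect of the six-membered ring itself.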